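Compound 4 and the limit of compound 3

The source may report more compounds than this note shows. Statements on the series, on what has been measured and on what is new or still open speak of the compounds shown alone.

In an ADME assay on SH-SY5Y cells (Homo sapiens) for cytotoxicity, read by MTT assay, with a stated time of 72 h (on this read-out higher numbers stand for weaker inhibition and lower numbers for stronger inhibition), compound 1 (`O=C(CN1CCN(C(=O)c2cccc(Br)c2)CC1)N1CCN(CCCc2c[nH]c3ccccc23)CC1`) gives 80500 nM and compound 2 (`COc1ccc(C(=O)N2CCN(CC(=O)N3CCN(CCCc4c[nH]c5ccc(OC)cc45)CC3)CC2)cc1`) gives 190000 nM as measured numbers. As far as these compounds go, compound 3 (`COc1ccc2[nH]cc(CCCN3CCN(C(=O)CN4CCN(C(=O)c5ccc(C)cc5)CC4)CC3)c2c1`) gives > 200000 nM and this is a limit, not a number, so its exact place on the scale is unknown.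

Compound 4 (`COc1ccc2[nH]cc(CCCN3CCN(C(=O)CN4CCN(C(=O)c5cccc(Br)c5)CC4)CC3)c2c1`) departs from compound 3 by a single change, 3-bromophenyl in place of 4-methylphenyl on a carbonyl carbon. For the measured compounds named here, the only measured step at this part of the series is an at least 1.0-fold higher number from compound 2 to compound 3 (0.02 log units; that floor lies within the scatter) for methyl in place of methoxy on an aromatic carbon, and it fixes no size for the present change. The closest guide is compound 1, which carries the same 3-bromophenyl on its carbonyl carbon and gives 80500 nM in this assay with a core that differs from that of compound 4.

On that single precedent, a modest move towards lower numbers and stronger inhibition is expected, though compound 4 could also return only a limit. The estimated change is an at least 1.6-fold lower number from compound 3 to compound 4 (0.22 log units; that floor lies within the scatter) and it remains loosely bounded. For compound 4 the expected value is 120000 nM (estimated range 60000 nM to 220000 nM).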

Compound 4, half-maximal inhibitory concentration: 105000 nM
Compound 4: the middle estimate sits 1.1-fold (0.06 log units) above what was measured, within the range that was stated.
By their numbers in this assay, from the lowest: compounds 1, 4 and 2 (each within the scatter of the next, the first and the last beyond it). At a limit, above all of these: compound 3.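

In this assay, 3-bromophenyl on the carbonyl carbon gives compound 4 a measured number on the shared core, whereas compound 3, with 4-methylphenyl at that place, stands only at a limit and not at a number: the limit of > 200000 nM in this assay, at which 1 of the 4 values shown sits.

The exchange of 4-methylphenyl reads as an at least 1.9-fold lower number from compound 3 to compound 4 (0.27 log units; that floor lies within the scatter), and the exchange of 4-methoxyphenyl on the same carbonyl carbon reads as a 1.8-fold lower number from compound 2 to compound 4 (0.26 log units; within the scatter), so neither shows a change beyond the scatter. For the compounds shown here, with 3-bromophenyl held in place, methoxy in place of hydrogen on an aromatic carbon gives a first reading of a 1.3-fold higher number from compound 1 to compound 4 (0.12 log units; within the scatter), and this step also shows no separation.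

As far as these compounds go, the true distance from compound 4 to compound 3 remains open, as only its floor can be read. The compounds shown also leave open what an amine or a carboxylic acid in place of the bromine on the 3-bromophenyl would give in this assay.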